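Sulfonylmethyl azoline series: oxygen for sulfur in the ring

The source may report more compounds than this note shows. Statements on the series, on what has been measured and on what is new or still open speak of the compounds shown alone.

Measured so far:
compound 1 `O=S(=O)(CC1=NCCO1)c1n[nH]cc1-c1ccc(Cl)cc1` gives "not active" (no number reported)
compound 2 `O=S(=O)(CC1=NCCO1)c1n[nH]cc1-c1ccccc1` gives 55.6%
compound 3 `Cc1ccc(-c2c[nH]nc2S(=O)(=O)CC2=NCCS2)cc1` gives "not active" (no number reported)

All three were run in a functional assay, tested at 75 ug/mL; on this read-out higher numbers stand for a stronger effect at the one concentration tested and lower numbers for a weaker effect. Among the compounds with values here, compound 2 is the only one with a number; in this assay compound 2 gives 55.6%. Within the data shown here, compound 1 and compound 3 stand without a number, each reported as inactive, so compound 3 sits at the bottom of what has been seen together with compound 1, and no step between measured compounds can be stated.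

Compound 4 `Cc1ccc(-c2c[nH]nc2S(=O)(=O)CC2=NCCO2)cc1` is the next entry. It differs from compound 3 by a group of 5 heavy atoms (3 carbon, 1 nitrogen, 1 oxygen; one five-membered non-aromatic ring with 2 hetero atoms) in place of a group of 5 heavy atoms (3 carbon, 1 nitrogen, 1 sulfur; one five-membered non-aromatic ring with 2 hetero atoms), on a saturated chain carbon bound to a sulfonyl sulfur. Among the measured compounds shown here, the ring that enters is the one found in compound 1 and compound 2, which between them show both an inactive result and a clear read-out, so the ring alone does not settle the outcome. For the measured compounds named here, no measured pair tells the size of this change. The expectation for this assay is a modest shift upward from compound 3, with real risk that compound 4 again comes back inactive.

Compound 4 is estimated at 25% in this assay, within 0% to 60%.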

Compound 4, a percentage reported as activity, at one concentration (the size of the read-out at that concentration, not a potency): 62%
The estimate for compound 4 lay 37 percentage points below the measured number, outside the stated range (above it).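

In this assay, within the data shown here, compound 3 gives "not active" (no number reported) while compound 4 gives 62%, so on a saturated chain carbon bound to a sulfonyl sulfur, the exchange of the sulfur-containing ring for the oxygen-containing ring separates an inactive entry from a clear read-out, the first comparison that isolates this change. With the oxygen-containing ring in place, methyl in place of hydrogen on an aromatic carbon gives a number 6.4 percentage points higher from compound 2 to compound 4 (within the scatter), so the methyl keeps the read-out of the unsubstituted compound, whereas compound 1, with chlorine in place of that methyl, gives "not active" (no number reported) and goes against any rule that the oxygen-containing ring alone is enough. Nothing at hand explains why the two rings part so sharply in this pair.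

Whether the oxygen-for-sulfur exchange has the same outcome with hydrogen or chlorine on the aromatic ring stays open, as the sulfur-containing counterparts of compound 1 and compound 2 are not among the compounds shown. Also open, going by these compounds, is how the read-out responds to an amine or a carboxylic acid in place of the methyl, or to a six-membered ring with the same hetero atoms on the chain carbon.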